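A few compounds are considered here, and "the series" means these few. Any claim that something is new, unique, unknown or untested is made for them only; others in the source may bear on it.

Measured in a functional assay on PC-3 cells (Homo sapiens) for antiproliferative activity, read by luminescence, with a stated time of 72 h; a higher number here means a weaker inhibitor, a lower number a stronger inhibitor:
- Compound 1 `CN1CC=C(c2c(O)cc(O)c3c(=O)cc(-c4ccc(Sc5nc6ccccc6[nH]5)cc4)oc23)CC1`: 742 nM
- Compound 2 `CN1CC=C(c2c(O)cc(O)c3c(=O)cc(-c4ccc(Sc5nc6ccccc6n5C)cc4Cl)oc23)CC1`: 85 nM
- Compound 3 `CN1CC=C(c2c(O)cc(O)c3c(=O)cc(-c4ccc(Sc5nc6ccccc6n5C)cc4)oc23)CC1`: 276 nM

Of these three, compound 2 has the lowest number and compound 1 the highest, while compound 3 stands second highest at 276 nM. Compound 4 `CN1CC=C(c2c(O)cc(O)c3c(=O)cc(-c4ccc(Sc5nc(-c6ccccc6)c[nH]5)cc4)oc23)CC1` departs from compound 3 at one place, with 4-phenyl-1H-imidazol-2-yl in place of 1-methyl-1H-benzimidazol-2-yl on a sulfur.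

Two measured steps lead to compound 3. One is a 3.2-fold higher number from compound 2 to compound 3 (0.51 log units; beyond the scatter), where hydrogen replaces chloro on an aromatic carbon. It has little bearing here, since compound 4 keeps the hydrogen of compound 3 at that place. The more relevant one is a 2.7-fold lower number from compound 1 to compound 3 (0.43 log units; beyond the scatter), where methyl replaces hydrogen on an aromatic nitrogen. Compound 4, like compound 1, has a hydrogen on an aromatic nitrogen, so part of that step may be reversed, and a small move towards a higher number is expected in this assay. Going by the values given here, no measured step covers the exchange of the ring groups themselves, which leaves the expectation uncertain in both directions. The expected step is a 1.8-fold higher number from compound 3 to compound 4 (0.26 log units; within the scatter). For compound 4 the estimated value is 500 nM, with an expected range of 150 nM to 1600 nM.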

Compound 4, half-maximal inhibitory concentration: 243 nM
Compound 4: middle estimate off by 2.1-fold (0.31 log units), on the high side; the range from low to high includes it.
By their numbers in this assay, from the lowest: compound 2; then compounds 4 and 3 (each within the scatter of the next); then compound 1.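

At this place on the sulfur, the single-ring 4-phenyl-1H-imidazol-2-yl group, with its phenyl attached, stands in for the fused 1-methyl-1H-benzimidazol-2-yl group of compound 3 without a change beyond the scatter in this assay (a 1.1-fold lower number from compound 3 to compound 4 (0.06 log units; within the scatter)). Compound 4 also carries a hydrogen on an aromatic nitrogen, as compound 1 does, yet it does not share the higher number of compound 1 (a 3.1-fold lower number from compound 1 to compound 4 (0.48 log units; beyond the scatter)), so among these compounds a hydrogen on that nitrogen does not by itself go with the weaker result. The data give no measured basis for explaining why these two groups match or why compound 4 departs from compound 1.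

From the compounds shown here alone, it remains open whether a 1-methyl-4-phenyl-1H-imidazol-2-yl group, with methyl in place of the hydrogen on the aromatic nitrogen, would move the number as methyl did between compound 1 and compound 3. Going by these compounds, it is equally open whether chloro on the aromatic carbon where compound 2 carries it would lower the number of compound 4 as it does for the 1-methyl-1H-benzimidazol-2-yl series, or whether an amine on the phenyl would be tolerated.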